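This account rests on a few compounds, and the source may have more. Where it says the series, first, only, none or still open, it means among the compounds named here.

Of the compounds shown here, two share a common core and have been measured in a functional assay on UO-31 cells (Homo sapiens) for cytotoxicity, read by sulforhodamine B assay, with a stated time of 48 h, tested at 100 nM; a higher number here means a weaker effect of the compound at the concentration tested, a lower number a stronger effect. Compound 1 `COc1cc(C)cc(-c2c(-c3ccnc(-c4ccc(C(C)=O)cc4)c3)cnn2CC#N)c1` gives 78% in this assay. Compound 2 `Cc1cc(O)cc(-c2nn(CC#N)cc2-c2ccnc(-c3ccc(Oc4ccccc4)cc3)c2)c1` gives 85% in this assay; this is the higher of the two numbers, yet the two values lie within the usual scatter of each other, so nothing can be said about which compound acts more strongly at this concentration. Within the data shown here, no step between measured compounds is available to guide expectations about structural changes.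

Compound 3 `Cc1cc(O)cc(-c2nn(CC#N)cc2-c2ccnc(-c3ccc(N(C)C)cc3)c2)c1` has not yet been measured. It differs from compound 2 in one place: dimethylamino in place of phenoxy on an aromatic carbon. Among the measured compounds shown here, with no comparable step on record, the step of a number 3 percentage points lower from compound 2 to compound 3 (within the scatter) is expected to be small, with no clear direction beyond the scatter. Compound 3 is therefore estimated to give 82% in this assay, within a range from 62% to 98%.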

Compound 3, a percentage reported as activity, at one concentration (the size of the read-out at that concentration, not a potency): 82%
Beside the measured number, compound 3's estimate shows no gap at the digits printed; the measured number falls inside the stated range.
By their numbers in this assay, from the lowest: compounds 1, 3 and 2 (each within the scatter of the next).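

In this assay, the change at this position gives a number 3 percentage points lower from compound 2 to compound 3 (within the scatter), so this step cannot be read as a gain or a loss of effect. Among these compounds, it is the first direct comparison at this position, on an aromatic carbon para to a large group, and it shows that phenoxy, with 7 heavy atoms and a ring, can give way to dimethylamino, with 3 heavy atoms and no ring, without a change beyond the scatter at this one concentration. Among the compounds shown here, nothing available explains this result, and the single pair sets no general rule for the position.

Going by these compounds, it remains open whether a carboxylic acid or a primary amine in the same place would move the read-out beyond the scatter. Also open, on these data alone, is whether a change elsewhere on the shared core would do so.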